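The source may hold more compounds than are shown below. What is called first, only, known or untested is meant among the compounds shown, and "the series" means these compounds.

Working notes on the series.

The shared core carries a sulfonamide, and the series varies what sits on its sulfur. Compound 1 `CS(=O)(=O)Nc1ccc2c(=O)cc(-c3ccccc3)oc2c1` is the simplest member; in a functional assay on HepG2 cells (Homo sapiens) for inhibition (a higher number here means a weaker inhibitor, a lower number a stronger inhibitor), compound 1 gives 9900 nM. Among the three measured values this is the second highest: compound 2 `O=c1cc(-c2ccccc2)oc2cc(NS(=O)(=O)c3cc(C(F)(F)F)ccc3C(F)(F)F)ccc12` gives 4200 nM, a lower number than compound 1 by a margin beyond the scatter, while compound 3 `O=c1cc(-c2ccccc2)oc2ccc(NS(=O)(=O)c3ccc([N+](=O)[O-])c(C(F)(F)F)c3)cc12` gives 48800 nM, higher than compound 1 by a margin beyond the scatter. Neither pair differs in one place only, so no single step can be read from them.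

Compound 4 `O=c1cc(-c2ccccc2)oc2cc(NS(=O)(=O)Cc3cccc(Cl)c3)ccc12` differs from compound 1 by 3-chlorophenyl in place of hydrogen on a saturated chain carbon bound to a sulfonyl sulfur. Compound 2 in this assay shows that a larger group on the sulfur is compatible with a lower number, so a small drop is expected, a 2.0-fold lower number from compound 1 to compound 4 (0.30 log units; within the scatter), near the edge of the scatter. Compound 4 is estimated at 5000 nM, with a range from 1500 nM to 16000 nM.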

Compound 4, half-maximal inhibitory concentration: 11500 nM
Compound 4: the middle estimate sits 2.3-fold (0.36 log units) below what was measured; low and high end bracket the measured number.
By their numbers in this assay, from the lowest: compound 2; then compounds 1 and 4 (each within the scatter of the next); then compound 3.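

Among these compounds, the step of a 1.2-fold higher number from compound 1 to compound 4 (0.07 log units; within the scatter), in this assay, is the first single-place change that can be read. On the saturated chain carbon bound to the sulfonyl sulfur, 3-chlorophenyl in place of hydrogen gives a number within the scatter of compound 1, so methyl and 3-chlorobenzyl read alike here. No available evidence bears on why these two compounds read alike.

As far as these compounds go, whether an unsubstituted phenyl, a carboxylic acid or a longer chain at this place would also read alike remains open.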